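The source may report more compounds than this note shows. Statements on the series, on what has been measured and on what is new or still open speak of the compounds shown alone.

Measured in a functional assay on HCT-15 cells (Homo sapiens) for inhibition, read by sulforhodamine B assay, with a stated time of 72 h; on this read-out higher numbers stand for weaker inhibition and lower numbers for stronger inhibition:
Compound 1 `C[C@H](OC(=O)/C=C\c1ccc(O)cc1)[C@@H]1CC[C@H]([C@H](O)[C@H]2CC=CC(=O)O2)O1`: > 10000 nM, a limit.
Compound 2 `C[C@H](OC(=O)/C=C/c1ccc(O)cc1)[C@@H]1CC[C@H]([C@H](O)[C@H]2CC=CC(=O)O2)O1`: > 10000 nM, a limit.

Compound 2 stands at no exact number, since its > 10000 nM is a limit of the assay. The same holds for the other measured compound, so the data offer only (the limit of > 10000 nM in this assay, at which 2 of the 2 values shown sit). Going by the values given here, the single measured step is a step that the two limits leave unreadable from compound 1 to compound 2, and it concerns (the fact that compounds 1 and 2 differ only in the configuration as drawn). It therefore gives no size to carry forward.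

Compound 3 `C[C@H](OC(=O)/C=C/c1ccc(O)c(O)c1)[C@@H]1CC[C@H]([C@H](O)[C@H]2CC=CC(=O)O2)O1` follows from compound 2 by hydroxy in place of hydrogen on an aromatic carbon. This places hydroxy in place of hydrogen on an aromatic carbon, ortho to a hydroxy group and meta to a large group, turning 4-hydroxyphenyl into 3,4-dihydroxyphenyl. Among the compounds with values here, no measured step covers this kind of change, so no direction can be drawn firmly from the data. The working expectation is no change beyond the scatter in this assay, with another reading at the limit quite likely. The expected step is a step that the limit leaves unreadable from compound 2 to compound 3. The estimated value for compound 3 is 12000 nM, with an expected range from 4000 nM to 30000 nM.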

Compound 3, half-maximal inhibitory concentration: > 10000 nM
Compound 3: a limit, no number; the forecaster's own chance of this, stated with the estimate: 65%; the middle value does not contradict the limit.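

In this assay compound 3 gives > 10000 nM, which is a limit. Compound 2 gives > 10000 nM, also a limit, so no size can be read for the change from 4-hydroxyphenyl to 3,4-dihydroxyphenyl between compound 2 and compound 3. The compounds shown leave open how strongly any of them inhibits, and what sets them apart: the limit of > 10000 nM in this assay, at which 3 of the 3 values shown sit.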